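Removing the bromo from compound 1: a benzamide series

The source may hold more compounds than are shown below. What is called first, only, known or untested is meant among the compounds shown, and "the series" means these compounds.

Measured so far:
compound 1 `COc1c(Br)cccc1C(=O)Nc1ccc(Sc2nc3ccccc3s2)c(Cl)c1` gives > 100000 nM in an assay for inhibition of HSP60/HSP10 (Homo sapiens), with a stated time of 60 min; a lower number here means a stronger inhibitor, a higher number a weaker inhibitor
compound 2 `COc1c(Br)cccc1C(=O)Nc1ccccc1` gives > 100000 nM in this assay
compound 3 `O=C(Nc1ccc(Sc2nc3ccccc3s2)cc1)c1ccccc1` gives > 100000 nM in this assay

Every value recorded so far in this assay is a limit of the assay rather than a number. Compound 1 sits at that limit, as do compound 2 and compound 3; the three are summarised by the limit of > 100000 nM in this assay, at which 3 of the 3 values shown sit. Going by the values given here, no ranking among them is possible, and no step between measured compounds can be worked out.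

Compound 4 `COc1ccccc1C(=O)Nc1ccc(Sc2nc3ccccc3s2)c(Cl)c1` differs from compound 1 in one place: hydrogen in place of bromo on an aromatic carbon. The change is small and removes a single heavy atom from the core shared with compound 1.

With nothing measured beyond the limit, the expectation for compound 4 rests only on compound 1 giving > 100000 nM in this assay. Compound 4 is expected to remain at or near that limit, so the step of a number no higher from compound 1 to compound 4 (the limit leaves the size open) is estimated as none beyond the scatter. Compound 4 is accordingly estimated at 100000 nM in this assay, within 30000 nM to 300000 nM, with a strong chance that only a limit is reported again.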

Compound 4, half-maximal inhibitory concentration: > 100000 nM
Compound 4 gave a limit, no number; the forecaster's own chance of this, stated with the estimate: 85%; the middle value lies on the limit itself.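

Compound 4 returns a limit rather than a number in this assay, as compound 1 does, so no step between compound 1 and compound 4 can be read: the limit of > 100000 nM in this assay, at which 4 of the 4 values shown sit.

The compounds shown leave open whether hydrogen in place of bromo changes inhibition at all, and which structure in this series would give a measurable value.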